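The source may hold more compounds than are shown below. What is called first, only, known or untested is meant among the compounds shown, and "the series" means these compounds.

Of the compounds shown here, three built on one shared core have been measured in a functional assay on SAOS-2 cells (Homo sapiens) for antiproliferative activity, read by MTT assay, with a stated time of 72 h; a lower number here means a stronger inhibitor, a higher number a weaker inhibitor. Compound 1 `CCCCOC1=C(C(=O)c2ccccc2)C(c2ccc(Br)cc2)N(CCCn2ccnc2)C1=O` gives 11600 nM. Compound 2 `Cc1ccc(NC2=C(C(=O)c3ccccc3)C(c3ccc(Br)cc3)N(CCCn3ccnc3)C2=O)cc1` gives 31900 nM, and compound 3 `O=C(C1=C(Nc2ccc(F)cc2)C(=O)N(CCCn2ccnc2)C1c1ccc(Br)cc1)c1ccccc1` gives 32700 nM. The step of a 2.8-fold higher number from compound 1 to compound 2 (0.44 log units; beyond the scatter) and the step of a 2.8-fold higher number from compound 1 to compound 3 (0.45 log units; beyond the scatter) are both modest and beyond the scatter, whereas the step of a 1.0-fold higher number from compound 2 to compound 3 (0.01 log units; within the scatter) lies within it. Compound 3 therefore stands at the high end of the three numbers, with compound 2 inside the scatter of it and compound 1 the furthest away.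

Compound 4 `O=C(C1=C(Nc2ccc(Cl)cc2)C(=O)N(CCCn2ccnc2)C1c1ccc(Br)cc1)c1ccccc1` differs from compound 3 in one place: chloro in place of fluoro on an aromatic carbon, an exchange on an aromatic carbon of a six-membered aromatic ring of carbon only, para to a large group, which read one bond further out is (4-fluorophenyl)amino to (4-chlorophenyl)amino. Among the compounds with values here, the only measured step at that same aromatic carbon is a 1.0-fold higher number from compound 2 to compound 3 (0.01 log units; within the scatter), and it is within the scatter. Within the data shown here, no step from fluoro to chloro has been measured here. On that basis compound 4 is expected to show in this assay a step of a 1.0-fold higher number from compound 3 to compound 4 (0.00 log units; within the scatter), that is, no change beyond the scatter. Compound 4 is accordingly estimated at 33000 nM, within a range from 15000 nM to 70000 nM.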

Compound 4, half-maximal inhibitory concentration: 24800 nM
The estimate for compound 4 lay 1.3-fold (0.12 log units) above the measured number, and the stated range covers the measured number.
By their numbers in this assay, from the lowest: compound 1; then compounds 4, 2 and 3 (each within the scatter of the next).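

In this assay, chloro in place of fluoro on an aromatic carbon of the six-membered ring gives a 1.3-fold lower number from compound 3 to compound 4 (0.12 log units; within the scatter) and chloro in place of methyl on that carbon gives a 1.3-fold lower number from compound 2 to compound 4 (0.11 log units; within the scatter), so methyl, fluoro and chloro at this place cannot be told apart by their numbers among the three compounds shown. The replacement of butoxy on the double-bonded ring carbon by (4-chlorophenyl)amino gives a 2.1-fold higher number from compound 1 to compound 4 (0.33 log units; beyond the scatter) and is modest, which means that compound 1 now stands apart, beyond the scatter, from each of the three compounds carrying a substituted phenylamino group at that carbon. The available data offer no evidence that would explain either the flat response at the aromatic carbon or the step away from butoxy. 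

On these data alone, what a methoxy group, a nitrile, a carboxylic acid or an unsubstituted hydrogen would do at the same aromatic carbon remains open, so the flat response is known only for these three substituents. Equally open, as far as these compounds go, is how a shorter alkoxy chain, a longer alkoxy chain or a simple alkylamine on the double-bonded ring carbon would compare with butoxy and the phenylamino groups.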